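This account rests on a few compounds, and the source may have more. Where it says the series, first, only, none or still open, it means among the compounds named here.

In a physicochemical assay for solubility, read by spectrophotometry, in phosphate buffer, with a stated time of 18 h, at pH 7.4 (on this read-out lower numbers stand for lower solubility and higher numbers for higher solubility), compound 1 `CCc1ccc(-c2nc3c(c(C)nn3-c3ccccc3)c(-c3ccccc3C#N)c2C#N)cc1` gives 2400 nM and stands level, within the scatter, with compound 2 `CCc1ccc(-c2nc3c(c(C)nn3-c3ccccc3)c(-c3ccccc3Br)c2C#N)cc1` at 1500 nM and compound 3 `CCc1ccc(-c2nc3c(c(C)nn3-c3ccccc3)c(-c3ccccc3Cl)c2C#N)cc1` at 1700 nM in this small set. Compound 4 `CCc1ccc(-c2nc3c(c(C)nn3-c3ccccc3)c(-c3ccccc3F)c2C#N)cc1` differs from compound 1 by fluoro in place of cyano on an aromatic carbon in one place: 2-cyanophenyl to 2-fluorophenyl. Two measured replacements of that cyano group bear on this change. Bromo shows a 1.6-fold lower number from compound 1 to compound 2 (0.20 log units; within the scatter) and chloro shows a 1.4-fold lower number from compound 1 to compound 3 (0.15 log units; within the scatter) while the exchange between those two shows a 1.1-fold higher number from compound 2 to compound 3 (0.05 log units; within the scatter) as well. All three stay within the scatter, so no step beyond it is expected in this assay for fluoro in place of cyano. The estimate for compound 4 is 1800 nM with an expected range (from 900 nM to 3500 nM). That estimate means a 1.3-fold lower number from compound 1 to compound 4 (0.12 log units; within the scatter) as the expected step.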

Compound 4, solubility: 1700 nM
Estimate against measurement, compound 4: 1.1-fold (0.02 log units) above; the measured number falls inside the stated range.
By their numbers in this assay, from the lowest: compounds 2, 3, 4 and 1 (each within the scatter of the next).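

In this assay, fluoro now joins bromo and chloro as a replacement for cyano on this aromatic carbon, with a 1.4-fold lower number from compound 1 to compound 4 (0.15 log units; within the scatter) and, among the halogens, no change at the digits printed from compound 3 to compound 4 (within the scatter) and a 1.1-fold higher number from compound 2 to compound 4 (0.05 log units; within the scatter). All four groups therefore read alike at this position, including the single-atom fluoro. No measurement offered here gives a reason for this sameness. Still open, on these data alone, is whether a group of another kind on this carbon, such as an amine or a carboxylic acid, would move the number beyond the scatter.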